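From Piperazinyl to Amino on the Sulfur-Linked Chain

A few compounds are considered here, and "the series" means these few. Any claim that something is new, unique, unknown or untested is made for them only; others in the source may bear on it.

Measured compounds:
Compound 1 `CC(C)c1n[nH]c2c(NCc3ccc(-c4ccccn4)cc3)nc(SCC(O)CN3CCNCC3)nc12`: 332 nM in a functional assay on HT cells (Homo sapiens) for antiproliferative activity, read by fluorescence, with a stated time of 72 h; a higher number here means a weaker inhibitor of growth, a lower number a stronger inhibitor of growth
Compound 2 `CC(C)c1n[nH]c2c(NCc3ccc(-c4ccccn4)cc3)nc(SC3CCCCC3O)nc12`: 636 nM in this assay
Compound 3 `CC(C)c1n[nH]c2c(NCc3ccc(-c4ccccn4)cc3)nc(SCCNC(N)=O)nc12`: 240 nM in this assay

The three measured compounds share the same core and differ only in the group carried on the sulfur. In this assay compound 1 stands second highest of the three numbers; its nearest neighbour is compound 3 and its furthest is compound 2, and both of those gaps are within the scatter. The move a 1.9-fold higher number from compound 1 to compound 2 (0.28 log units; within the scatter) and the move a 1.4-fold lower number from compound 1 to compound 3 (0.14 log units; within the scatter) therefore show no real change, while only a 2.7-fold lower number from compound 2 to compound 3 (0.42 log units; beyond the scatter) reaches beyond it, and modestly so.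

Compound 4 `CC(C)c1n[nH]c2c(NCc3ccc(-c4ccccn4)cc3)nc(SC[C@H](O)CN)nc12` is not yet measured. It differs from compound 1 by 2-amino-1-hydroxyethyl in place of 1-hydroxy-2-(piperazin-1-yl)ethyl on a saturated chain carbon bound to a sulfur. Among the measured compounds shown here, the steps that bear on this change, those from compound 1 to compound 2 and from compound 1 to compound 3, show that swapping the group on the sulfur for other small hydroxylated or polar chains has left the number within the scatter. On that basis the step of a 1.1-fold higher number from compound 1 to compound 4 (0.02 log units; within the scatter) is expected to stay within the scatter as well, with no clear direction. Compound 4 is thus estimated at 350 nM, in a range from 150 nM to 800 nM.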

Compound 4, concentration for 50% growth inhibition: 63 nM
The estimate for compound 4 lay 5.6-fold (0.74 log units) above the measured number, outside the stated range (below it).
By their numbers in this assay, from the lowest: compound 4; then compounds 3, 1 and 2 (each within the scatter of the next, the first and the last beyond it).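

Replacing 2-hydroxy-3-(piperazin-1-yl)propyl with 3-amino-2-hydroxypropyl on the sulfur in this assay brings a clear shift (a 5.3-fold lower number from compound 1 to compound 4 (0.72 log units; beyond the scatter)), although compound 1 had stayed within the scatter of both compound 2 and compound 3, so this position can move the number more than those earlier steps showed. The 2-amino-1-hydroxyethyl group also separates from ureidomethyl on the same saturated chain carbon (a 3.8-fold lower number from compound 3 to compound 4 (0.58 log units; beyond the scatter)), and 3-amino-2-hydroxypropyl separates from 2-hydroxycyclohexyl on the sulfur (a 10-fold lower number from compound 2 to compound 4 (1.00 log units; beyond the scatter)), which makes compound 4 the only one of the four whose steps to all the others lie beyond the scatter. Nothing in the data shown offers an explanation for this gain.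

The compounds shown leave open whether the result depends on the hydroxyl, which a plain 3-aminopropyl chain on the sulfur would address, or on the free terminal amine, which a dimethylamino group in its place would address. They also leave open how a chain one carbon longer, or the opposite configuration at the defined stereocentre of compound 4, would read.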